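The source may report more compounds than this note shows. Statements on the series, on what has been measured and on what is new or still open speak of the compounds shown alone.

In a functional assay on A549 cells (Homo sapiens) for inhibition, read by MTT assay, with a stated time of 72 h (on this read-out lower numbers stand for stronger inhibition and higher numbers for weaker inhibition), compound 1 `O=C(Nc1ccc(Oc2ccnc3[nH]ccc23)cc1)c1cn(-c2ccccc2)c2ccccc2c1=O` gives 1030 nM, compound 2 `O=C(Nc1ccc(Oc2ccnc3[nH]ccc23)cc1)c1cn(-c2ccc(C(F)(F)F)cc2Cl)c2ccccc2c1=O` gives 2350 nM, and compound 3 `Cn1ccc2c(Oc3ccc(NC(=O)c4cn(-c5ccccc5)c5ccccc5c4=O)cc3F)ccnc21` gives 1720 nM. Compound 3 therefore sits second highest of the three numbers; its gap to compound 2 and its gap to compound 1 both lie within the scatter, so no order among the three can be read from these values.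

Compound 4 `Cn1ccc2c(Oc3ccc(NC(=O)c4cn(-c5ccc(C(F)(F)F)cc5Cl)c5ccccc5c4=O)cc3F)ccnc21` is not yet measured. It differs from compound 3 only in one place: 2-chloro-4-(trifluoromethyl)phenyl in place of phenyl on an aromatic nitrogen. The same exchange has been made once before among the measured compounds, on the shared core without the fluorine and the methyl of compound 3, and there it gave a 2.3-fold higher number from compound 1 to compound 2 (0.36 log units; beyond the scatter), a modest weakening that nevertheless lay beyond the scatter.

Going by the values given here, with only this single precedent to rest on, the expectation for compound 4 is a step of about the same size and in the same direction, a weakening, because the step of a 2.3-fold higher number from compound 1 to compound 2 (0.36 log units; beyond the scatter) is the only guide. Compound 4 is therefore estimated at 3800 nM, within a range from 1700 nM to 8500 nM, which means an expected step of a 2.2-fold higher number from compound 3 to compound 4 (0.34 log units; beyond the scatter).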

Compound 4, half-maximal inhibitory concentration: 2050 nM
Compound 4: the middle estimate sits 1.9-fold (0.27 log units) above what was measured; the measured number falls inside the stated range.
By their numbers in this assay, from the lowest: compounds 1, 3, 4 and 2 (each within the scatter of the next, the first and the last beyond it).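

In this assay, the exchange of phenyl for 2-chloro-4-(trifluoromethyl)phenyl on the aromatic nitrogen, made on the core that carries the fluorine and the methyl, gives a 1.2-fold higher number from compound 3 to compound 4 (0.08 log units; within the scatter), a step too small to read as a change. The earlier compounds shown here alone showed this exchange only as a modest weakening, and this second case shows that such a weakening does not have to appear on every core. Yet the two cores cannot be said to respond differently, and the size of the effect at this position remains unsettled, with the earlier step and the new one agreeing as closely as two such steps can be expected to: the same change on two cores in this assay, a 2.3-fold higher number (0.36 log units; beyond the scatter) from compound 1 to compound 2 and a 1.2-fold higher number (0.08 log units; within the scatter) from compound 3 to compound 4, 1.9-fold (0.28 log units) apart, within the scatter of two such steps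

The compounds shown leave open what the chlorine and the trifluoromethyl each contribute, since they enter together, and how the fluorine and the methyl on the core act separately, since they always appear as a pair. Going by these compounds alone, only two aryl groups, each with a six-membered ring of carbon only, occupy this nitrogen, so it also remains open how a small alkyl chain, or a phenyl ring bearing an amine or a carboxylic acid, would fare there.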